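A few compounds are considered here, and "the series" means these few. Any claim that something is new, unique, unknown or untested is made for them only; others in the source may bear on it.

Measured in a functional assay on the whole organism for antagonist activity, with Mus musculus as the target; on this read-out lower numbers stand for an effect already at smaller amounts and higher numbers for an effect only at larger amounts of compound:
- Compound 1 `CN(C)C1CCCC1N(C=O)c1ccccc1`: > 50 mg/kg (a limit)
- Compound 2 `CCC(=O)N(c1c(F)c(F)c(F)c(F)c1F)C1CCCC1N(C)C`: > 50 mg/kg (a limit)
- Compound 3 `CCNC1CCCC1N(C(=O)CC)c1ccc(Cl)c(Cl)c1`: 2 mg/kg

Among the measured compounds shown here, compound 3 holds the only actual number, 2 mg/kg. The other two entries are limits. Compound 4 `CCC(=O)N(c1ccc(Cl)c(Cl)c1)C1CCCC1N(C)CCN(C)C` carries (2-(dimethylamino)ethyl)(methyl)amino in place of ethylamino on a saturated ring carbon. For the measured compounds named here, no measured pair isolates this change. Starting from compound 3 at 2 mg/kg, a move toward larger doses, beyond the scatter, is expected in this assay. The expected size is a 5.0-fold higher number from compound 3 to compound 4 (0.70 log units; beyond the scatter). A result at the limit remains possible, given (the limit of > 50 mg/kg in this assay, at which 2 of the 3 values shown sit). For compound 4 the estimated value is 10 mg/kg, with an expected range of 2.5 mg/kg to 40 mg/kg.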

Compound 4, dose for half-maximal effect: 5 mg/kg
Estimate against measurement, compound 4: 2.0-fold (0.30 log units) above; the measured number falls inside the stated range.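

In this assay, replacing ethylamino with the larger (2-(dimethylamino)ethyl)(methyl)amino on this saturated ring carbon gives a 2.5-fold higher number from compound 3 to compound 4 (0.40 log units; beyond the scatter), the first step read at this position. The position therefore accepts this much larger group at a modest cost. Compound 4 returns an actual number, not the limit seen elsewhere in the series: the limit of > 50 mg/kg in this assay, at which 2 of the 4 values shown sit.

Going by these compounds, it remains open whether the step follows from the methyl on the attached nitrogen or from the dimethylaminoethyl chain, since both change together. Simple methylamino or a morpholine at this position would separate these contributions.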